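This account rests on a few compounds, and the source may have more. Where it says the series, first, only, none or still open, it means among the compounds named here.

Compound 1 `CC(=O)Oc1ccc(/C=C/C(=O)OCCSc2nc(-c3ccc(S(C)(=O)=O)cc3)n(-c3ccc(C(F)(F)F)cc3)n2)cc1OC(C)=O`: 1060 nM. Compound 2 `COc1cc(/C=C/C(=O)OCCSc2nc(-c3ccc(S(C)(=O)=O)cc3)n(-c3ccc(Br)cc3)n2)ccc1OC(C)=O`: 940 nM. Compound 3 `COc1cc(/C=C/C(=O)OCCSc2nc(-c3ccc(S(C)(=O)=O)cc3)n(-c3ccc(C)cc3)n2)ccc1OC(C)=O`: 980 nM.

In an assay on cells (strain Sprague-Dawley) for inhibition of Polyunsaturated fatty acid 5-lipoxygenase (Rattus norvegicus), with a stated time of 30 min (on this read-out higher numbers stand for weaker inhibition and lower numbers for stronger inhibition), compound 3 gives a number that lies within the usual scatter of the numbers for compound 2 and for compound 1. Compound 4 `COc1cc(/C=C/C(=O)OCCSc2nc(-c3ccc(S(C)(=O)=O)cc3)n(-c3ccc(C(F)(F)F)cc3)n2)ccc1OC(C)=O` differs from compound 3 by trifluoromethyl in place of methyl on an aromatic carbon. Within the data shown here, one measured step bears on this position: a 1.0-fold higher number from compound 2 to compound 3 (0.02 log units; within the scatter). Compound 1 also carries a trifluoromethyl at this place but differs elsewhere as well, and compound 1 gives 1060 nM, close to the number for compound 3. Exchanging the group on this ring has so far moved nothing beyond the scatter, so compound 4 is expected to show a 1.0-fold higher number from compound 3 to compound 4 (0.01 log units; within the scatter), that is, no step beyond the scatter. Compound 4 is therefore estimated at 1000 nM, between 500 nM and 2000 nM.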

Compound 4, half-maximal inhibitory concentration: 920 nM
Estimate against measurement, compound 4: 1.1-fold (0.04 log units) above; the range from low to high includes it.
By their numbers in this assay, from the lowest: compounds 4, 2, 3 and 1 (each within the scatter of the next).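

In this assay, trifluoromethyl now joins bromo and methyl at this place on the ring with no step beyond the scatter: a 1.1-fold lower number from compound 3 to compound 4 (0.03 log units; within the scatter), and a 1.0-fold lower number from compound 2 to compound 4 (0.01 log units; within the scatter). A second place also comes into view, since methyl in place of acetyl on an oxygen on an aromatic ring gives a 1.2-fold lower number from compound 1 to compound 4 (0.06 log units; within the scatter), again within the scatter. No measured evidence is available to explain why these changes leave the number in place.

The compounds shown leave open whether an amine or a carboxylic acid at this place on the ring, or a longer chain on that oxygen, would give a step beyond the scatter.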